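Removing the Methoxy Group from the Aryl Substituent

A few compounds are considered here, and "the series" means these few. Any claim that something is new, unique, unknown or untested is made for them only; others in the source may bear on it.

Three compounds share one core and differ only in the aromatic ring attached to a nitrogen of that core. Compound 1 `COc1ccc(-n2c(=O)n(CCN3CCN(c4ccccc4)CC3)c3ccccc32)cc1` gives 566 nM in an assay on HEK293 cells for displacement of a labelled ligand from 5-hydroxytryptamine receptor 7 (Homo sapiens); on this read-out lower numbers stand for stronger inhibition and higher numbers for weaker inhibition. Compound 2 `Cc1ccccc1-n1c(=O)n(CCN2CCN(c3ccccc3)CC2)c2ccccc21` gives 902 nM and compound 3 `COc1cccc(-n2c(=O)n(CCN3CCN(c4ccccc4)CC3)c3ccccc32)c1` gives 864 nM. Compound 3 stands second highest of these three numbers, yet all three lie within the scatter of one another: a 1.6-fold higher number from compound 1 to compound 2 (0.20 log units; within the scatter), a 1.5-fold higher number from compound 1 to compound 3 (0.18 log units; within the scatter), and a 1.0-fold lower number from compound 2 to compound 3 (0.02 log units; within the scatter).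

Compound 4 `O=c1n(CCN2CCN(c3ccccc3)CC2)c2ccccc2n1-c1ccccc1` has not yet been measured. It differs from compound 3 in one place: hydrogen in place of methoxy on an aromatic carbon. Going by the values given here, none of the measured steps removes a group outright; each swaps one substituted ring for another, and each stayed within the scatter. Among the compounds with values here, those steps suggest that the ring attached to this nitrogen tolerates such changes without a shift beyond the scatter, though with only three compounds this is a thin basis. For compound 4 a step of a 1.1-fold lower number from compound 3 to compound 4 (0.03 log units; within the scatter) is expected, meaning no change beyond the scatter. Compound 4 is estimated at 800 nM, with a range from 350 nM to 1800 nM.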

Compound 4, inhibition constant: 1230 nM
For compound 4 the middle estimate is 1.5-fold (0.19 log units) below the measured one; the measured number falls inside the stated range.
By their numbers in this assay, from the lowest: compounds 1, 3, 2 and 4 (each within the scatter of the next, the first and the last beyond it).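

Going by these compounds alone, this is the first step that takes a group off the ring outright instead of swapping one substituted ring for another. In this assay, removing the methoxy gives (a 1.4-fold higher number from compound 3 to compound 4 (0.15 log units; within the scatter)) and removing the methyl gives (a 1.4-fold higher number from compound 2 to compound 4 (0.13 log units; within the scatter)), so the bare phenyl ring stays within the scatter of both of these substituted rings. Against the 4-methoxyphenyl ring, however, the unsubstituted ring shows a first, modest gap (a 2.2-fold higher number from compound 1 to compound 4 (0.34 log units; beyond the scatter)), and no measurement here explains it.

An amine, a carboxylic acid or a longer chain on this ring could behave quite differently from the small groups shown, so how much this position tolerates remains open. On these data alone, whether the gap between the 4-methoxyphenyl and phenyl rings persists when another part of the shared core changes also remains open.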